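Swapping a dichlorobenzyl group across two related cores

A few compounds are considered here, and "the series" means these few. Any claim that something is new, unique, unknown or untested is made for them only; others in the source may bear on it.

Four compounds are built from the same atoms, joined differently. Compound 3 `C=CCc1ccc(OCc2c(Cl)cccc2Cl)c(-c2ccc(O)c(CC=C)c2)c1` gives 19400 nM in a functional assay on MCF7 cells (Homo sapiens) for inhibition, read by MTT assay, with a stated time of 72 h; on this read-out higher numbers stand for weaker inhibition and lower numbers for stronger inhibition. Compound 1 `C=CCc1ccc(OCc2ccc(Cl)cc2Cl)c(-c2ccc(O)c(CC=C)c2)c1` differs from it only by 2,4-dichlorophenyl in place of 2,6-dichlorophenyl on a saturated chain carbon bound to an oxygen on an aromatic ring, and in this assay compound 1 gives 27400 nM; the step is a 1.4-fold higher number from compound 3 to compound 1 (0.15 log units; within the scatter). Compound 2 `C=CCc1ccc(O)c(-c2ccc(OCc3c(Cl)cccc3Cl)c(CC=C)c2)c1` has a different core from compound 3, and the difference between the two cores is not broken down here. In this assay compound 2 gives 11500 nM. Compound 4 `C=CCc1ccc(O)c(-c2ccc(OCc3ccc(Cl)cc3Cl)c(CC=C)c2)c1` is not yet measured and differs from compound 2 by the same change, (2,4-dichlorophenyl in place of 2,6-dichlorophenyl on a saturated chain carbon bound to an oxygen on an aromatic ring). Because the earlier step of a 1.4-fold higher number from compound 3 to compound 1 (0.15 log units; within the scatter) stayed within the scatter, the new step is expected to be small as well, a 1.4-fold higher number from compound 2 to compound 4 (0.14 log units; within the scatter). Compound 4 is therefore expected to give about 16000 nM in this assay, most likely between 8000 nM and 32000 nM.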

Compound 4, half-maximal inhibitory concentration: 14700 nM
The estimate for compound 4 lay 1.1-fold (0.04 log units) above the measured number; low and high end bracket the measured number.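

Changing 2,6-dichlorobenzyl to 2,4-dichlorobenzyl gives a 1.3-fold higher number from compound 2 to compound 4 (0.11 log units; within the scatter) in this assay, so this swap again makes no clear difference. The two cores respond alike to this change: the same change on two cores in this assay, a 1.4-fold higher number (0.15 log units; within the scatter) from compound 3 to compound 1 and a 1.3-fold higher number (0.11 log units; within the scatter) from compound 2 to compound 4, 1.1-fold (0.04 log units) apart, within the scatter of two such steps. This shows that a swap with little effect on one core also had little effect on the other, but it does not show that a swap with a large effect would carry over in the same way, and two cores are a small sample.

Still open, going by these compounds, is what other groups on this saturated chain carbon would do, such as an unsubstituted phenyl or a phenyl bearing an amine or a carboxylic acid. Also open, on these data alone, is whether the same small step would appear on other cell lines.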